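The source may hold more compounds than are shown below. What is called first, only, known or untested is meant among the compounds shown, and "the series" means these compounds.

Notes on the series. In a functional assay on the whole organism with Rattus norvegicus as the target (on this read-out higher numbers stand for an effect only at larger amounts of compound and lower numbers for an effect already at smaller amounts), compound 1 `C=CCn1c(=N)sc2cc(OC(F)(F)F)ccc21` gives 7 mg/kg. Compound 2 `N=c1sc2cc(OC(F)(F)F)ccc2n1CC(=O)O` returns only a limit of this assay, > 10 mg/kg, the value (the limit of > 10 mg/kg in this assay, at which 1 of the 3 values shown sits). Compound 3 `CNS(=O)(=O)CCn1c(=N)sc2cc(OC(F)(F)F)ccc21` gives 4 mg/kg, the nearest measured number being that of compound 1, with the gap within the scatter. The steps measured at the same saturated chain carbon are a 1.8-fold lower number from compound 1 to compound 3 (0.24 log units; within the scatter) and an at least 2.5-fold lower number from compound 2 to compound 3 (0.39 log units; beyond the scatter). Compound 4 `C[S+]([O-])Cn1c(=N)sc2cc(OC(F)(F)F)ccc21` differs from compound 3 by a group of 3 heavy atoms (1 carbon, 1 oxygen, 1 sulfur; no ring) in place of a group of 6 heavy atoms (2 carbon, 1 nitrogen, 2 oxygen, 1 sulfur; no ring), on a saturated chain carbon bound to an aromatic nitrogen. Among the measured compounds shown here, the only step beyond the scatter here runs from a limit, and the others stay within it, so for compound 4 the expected step is a 1.5-fold higher number from compound 3 to compound 4 (0.18 log units; within the scatter) in this assay, with no direction beyond the scatter. Compound 4 is estimated at 6 mg/kg, between 2.5 mg/kg and 14 mg/kg.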

Compound 4, dose for half-maximal effect: 2.3 mg/kg
Beside the measured number, compound 4's estimate is 2.6-fold (0.42 log units) above it; the whole stated range lies above it.
By their numbers in this assay, from the lowest: compounds 4, 3 and 1 (each within the scatter of the next, the first and the last beyond it). At a limit, above all of these: compound 2.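

Working from this assay, the group entering in compound 4 gives the first step beyond the scatter at this saturated chain carbon that starts from a measured number (a 3.0-fold lower number from compound 1 to compound 4 (0.48 log units; beyond the scatter)). Against (methylsulfamoyl)methyl the step stays within the scatter (a 1.7-fold lower number from compound 3 to compound 4 (0.24 log units; within the scatter)), so the hydrogen-bond donor and the larger group of compound 3 are not needed to keep the number this low. Compound 2 stands only at a limit, so its step is a floor (an at least 4.3-fold lower number from compound 2 to compound 4 (0.63 log units; beyond the scatter)).

Going by these compounds, how an amine, a sulfone or a longer chain would read at this carbon stays open. So does whether the sulfur-bearing groups differ from each other at all, given the scatter.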